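A hydroxyphenyl gives way to an iodophenyl

The source may hold more compounds than are shown below. What is called first, only, known or untested is meant among the compounds shown, and "the series" means these compounds.

Compound 1 `COC(=O)C1=C(C)N=C(C)/C(=C(\O)OC)C1c1cc(Cl)cc(Cl)c1`: 93.3 nM
Compound 2 `COC(=O)C1=C(C)N=C(C)/C(=C(\O)OC)C1c1cccc(O)c1`: 1000 nM
Compound 3 `COC(=O)C1=C(C)N=C(C)/C(=C(\O)OC)C1c1ccc(I)cc1`: not yet measured

In a functional assay (muscle tissue) with Cavia porcellus as the target (on this read-out lower numbers stand for an effect already at smaller amounts and higher numbers for an effect only at larger amounts of compound), compound 2 has the higher of the two numbers (1000 nM), and compound 1 lies clearly lower (93.3 nM). Compound 3 carries 4-iodophenyl in place of 3-hydroxyphenyl on a saturated ring carbon. Among the measured compounds shown here, only one measured step bears on this change, and it is large (an 11-fold higher number from compound 1 to compound 2 (1.03 log units; beyond the scatter)). It exchanged 3,5-dichlorophenyl for 3-hydroxyphenyl on that same ring carbon. Compound 3 resembles compound 1 in having halogen rather than hydroxy on the phenyl, but the halogen and its place both differ, so only part of that step is expected to return. The move expected in this assay is estimated to be a 1.7-fold lower number from compound 2 to compound 3 (0.22 log units; within the scatter). For compound 3 the estimated value is 600 nM (expected range 150 nM to 2500 nM).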

Compound 3, half-maximal effective concentration: 22900 nM
Estimate against measurement, compound 3: 38-fold (1.58 log units) below; the whole stated range lies below it.
By their numbers in this assay, from the lowest: compound 1; then compound 2; then compound 3.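

Placing 4-iodophenyl on this saturated ring carbon in this assay gives a 23-fold higher number from compound 2 to compound 3 (1.36 log units; beyond the scatter) and also a 250-fold higher number from compound 1 to compound 3 (2.39 log units; beyond the scatter) when set against the 3,5-dichlorophenyl group. A halogen on the phenyl therefore does not by itself bring the low number of compound 1: compound 3 also carries one, yet it has the highest number of the three, above even the 3-hydroxyphenyl of compound 2. Nothing available here explains why the number rises so far with this change.

Still open, from the compounds shown here alone, is whether the iodine itself or its place on the phenyl drives the rise, as the two change together between compound 1 and compound 3. A 4-chlorophenyl and a 3-iodophenyl on the same carbon would pull those two apart, and a 4-aminophenyl would extend the comparison beyond halogen and hydroxy.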